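The source may report more compounds than this note shows. Statements on the series, on what has been measured and on what is new or still open speak of the compounds shown alone.

Measured in an ADME assay on the whole organism (strain CD-1) for pharmacokinetics, with Mus musculus as the target, at a dose of 3 mg/kg by the intravenous route; a lower number here means less compound in the circulation, a higher number more compound in the circulation at the dose given:
- compound 1 `CN(Cc1ccccc1OCCCCC(C)(C)C(=O)O)C(=O)c1ccc(-c2ccco2)cc1`: 48400 ng.h/mL
- compound 2 `CN(Cc1ccccc1OCCC[C@@H]1C[C@@H]1C(=O)O)C(=O)c1ccc(-c2ccco2)cc1`: 30100 ng.h/mL
- compound 3 `CN(Cc1ccccc1OCCC/C=C/C(=O)O)C(=O)c1ccc(-c2ccco2)cc1`: 750 ng.h/mL

Compound 3 is the lowest of the three, well clear of both others. The next structure is compound 4 `CC(CCOc1ccccc1CN(C)C(=O)c1ccc(-c2ccco2)cc1)CCC(=O)O`, which has 3-carboxy-1-methylpropyl in place of 3-carboxyprop-2-en-1-yl on a saturated chain carbon, two bonds along the chain from an oxygen on an aromatic ring.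

For the measured compounds named here, no measured step makes this exact change. The nearest evidence is a 65-fold lower number from compound 1 to compound 3 (1.81 log units; beyond the scatter) and a 40-fold lower number from compound 2 to compound 3 (1.60 log units; beyond the scatter), both large, while a 1.6-fold lower number from compound 1 to compound 2 (0.21 log units; within the scatter) stays within the scatter. Compound 4 shares the absence of a chain double bond with compound 1 and compound 2, but carries neither the 2-carboxy-2-methylpropyl of compound 1 nor the 2-carboxycyclopropyl of compound 2. Only a partial recovery is therefore expected in this assay. The expected upward move is a 5.3-fold higher number from compound 3 to compound 4 (0.73 log units; beyond the scatter). The estimate for compound 4 is 4000 ng.h/mL, with an expected range of 900 ng.h/mL to 18000 ng.h/mL.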

Compound 4, area under the concentration-time curve: 11800 ng.h/mL
Beside the measured number, compound 4's estimate is 3.0-fold (0.47 log units) below it; low and high end bracket the measured number.
By their numbers in this assay, from the lowest: compound 3; then compound 4; then compounds 2 and 1 (each within the scatter of the next).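

In this assay, 3-carboxy-1-methylpropyl in place of 3-carboxyprop-2-en-1-yl gives a 16-fold higher number from compound 3 to compound 4 (1.20 log units; beyond the scatter), so a large gain at this position does not need a ring or the gem-dimethyl branching of the other saturated chains. The gain stops short of those chains, with a 2.6-fold lower number from compound 2 to compound 4 (0.41 log units; beyond the scatter) and a 4.1-fold lower number from compound 1 to compound 4 (0.61 log units; beyond the scatter), both modest, so the form of the saturated chain still matters in this small set. Nothing measured here accounts for any of these steps.

Compound 4 both loses the chain double bond and gains a methyl, so the share of each in the step remains unresolved. On these data alone, an unbranched saturated chain would separate the two, and the effect of a longer chain at this position is also open.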